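The source may report more compounds than this note shows. Statements on the series, on what has been measured and on what is new or still open speak of the compounds shown alone.

Measured compounds:

Compound 1, `Cc1nc2c([nH]1)C(=O)/C(=N/c1ccc(Cl)cc1Cl)C(Cl)=C2O`: 1200 nM
Compound 2, `Cc1nc2c([nH]1)C(=O)/C(=N/c1ccc(F)cc1)C(Cl)=C2O`: 1200 nM
Compound 3, `Cc1nc2c([nH]1)C(=O)/C(=N/c1ccc(F)c(F)c1F)C(Cl)=C2O`: 1600 nM

All three share one core and differ only in the aromatic ring attached through the imine nitrogen. In a functional assay on NIH3T3 cells (Mus musculus) for antiproliferative activity (on this read-out lower numbers stand for stronger inhibition and higher numbers for weaker inhibition), compound 3 gives 1600 nM, the highest of the three numbers, yet its gaps to compound 1 and to compound 2 both lie within the usual scatter of repeated measurements, so nothing separates the three in this assay.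

Compound 4, `Cc1nc2c([nH]1)C(=O)/C(=N/c1ccc(F)cc1F)C(Cl)=C2O`, has not yet been measured in this assay. The change from compound 3 is hydrogen in place of fluoro on an aromatic carbon: a fluoro leaves and a hydrogen enters, on an aromatic carbon of a six-membered aromatic ring of carbon only, ortho to two fluoro groups and meta to a large group. Since compound 1, compound 2 and compound 3 carry quite different substitution on this ring and still give numbers within the scatter of each other, removing one fluoro is not expected to move the number beyond the scatter in either direction. Compound 4 is therefore estimated at 1400 nM, within a range from 700 nM to 2800 nM, which means an expected step of a 1.1-fold lower number from compound 3 to compound 4 (0.06 log units; within the scatter).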

Compound 4, half-maximal inhibitory concentration: 800 nM
The estimate for compound 4 lay 1.8-fold (0.24 log units) above the measured number, within the range that was stated.
By their numbers in this assay, from the lowest: compounds 4, 1, 2 and 3 (each within the scatter of the next).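

Within the data shown here, these are the first comparisons on this ring that change a single place. In this assay, swapping a fluoro for a hydrogen at the aromatic carbon ortho to two fluoro groups and meta to a large group gives a 2.0-fold lower number from compound 3 to compound 4 (0.30 log units; within the scatter) and so stays within the scatter, while adding a fluoro on an aromatic carbon gives a 1.5-fold lower number from compound 2 to compound 4 (0.18 log units; within the scatter) and also stays within it. Neither the loss nor the gain of one fluoro therefore separates these compounds on this read-out, and no supporting measurement is available to explain these steps.

On these data alone, what remains open is how this position responds to groups other than hydrogen and fluoro. An amine, a methoxy group or a carboxylic acid there could stay within the scatter or move the number beyond it.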